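The source may hold more compounds than are shown below. What is called first, only, known or untested is meant among the compounds shown, and "the series" means these compounds.

Going by the values given here, compound 2 `CC(C)[C@H](NC(=O)COc1cccc2ccccc12)C(=O)N[C@@H](CC(=O)O)C(=O)COc1c(F)cccc1F` is one of two compounds measured in a functional assay with Homo sapiens as the target; on this read-out lower numbers stand for stronger inhibition and higher numbers for weaker inhibition. In this assay compound 2 reaches only the limit of the measurement, > 100000 nM, so its true number is not known. Its measured partner is compound 1 `CC(C)[C@H](NC(=O)COc1cccc2ccccc12)C(=O)N[C@@H](CC(=O)O)C(=O)COC(=O)c1c(Cl)cccc1Cl`, which in this assay gives 11500 nM; the step between them is an at least 8.6-fold higher number from compound 1 to compound 2 (0.93 log units; beyond the scatter). Compound 3 `CC(C)[C@H](NC(=O)COc1cccc2ccccc12)C(=O)N[C@@H](CC(=O)O)C(=O)COc1cc(F)cc(F)c1` has not yet been measured, and it differs from compound 2 by 3,5-difluorophenyl in place of 2,6-difluorophenyl on an oxygen on a saturated carbon. Among the compounds with values here, neither measured step involves moving the two fluorine atoms to other places on the same ring, so no measured step bears directly on this change, and nothing seen so far points to a step beyond the scatter in either direction. Because compound 2 sits at the limit of > 100000 nM in this assay, at which 1 of the 2 values shown sits, any measurement of compound 3 is likely to end at a limit as well. Compound 3 is therefore expected to give about 150000 nM, probably between 30000 nM and 800000 nM, an expected step that the limit leaves unreadable from compound 2 to compound 3.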

Compound 3, half-maximal inhibitory concentration: 15900 nM
Compound 3: middle estimate off by 9.4-fold (0.97 log units), on the high side, outside the stated range (below it).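

In this assay, where the two fluorines sit on the ring clearly matters: with the same atoms joined differently, 3,5-difluorophenyl in place of 2,6-difluorophenyl gives an at least 6.2-fold lower number from compound 2 to compound 3 (0.79 log units; beyond the scatter). On these data alone, compound 2 stands at a limit, so the true size of that step stays unknown: the limit of > 100000 nM in this assay, at which 1 of the 3 values shown sits. Going by these compounds alone, the (2,6-dichlorophenyl)carbonyl group is also not the only group on this oxygen that gives a readable number, as the change to 3,5-difluorophenyl gives a 1.4-fold higher number from compound 1 to compound 3 (0.14 log units; within the scatter).

The compounds shown leave open whether other groups, such as 3,5-dichlorophenyl or 3,5-dimethoxyphenyl, would give a number similar to that of 3,5-difluorophenyl, and how plain phenyl would compare. They also give no reason why moving the fluorines changes the number.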